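The source may report more compounds than this note shows. Statements on the series, on what has been measured and on what is new or still open speak of the compounds shown alone.

Values measured so far in a physicochemical assay for lipophilicity; on this read-out higher numbers stand for higher lipophilicity and lower numbers for lower lipophilicity:

- compound 1 `CCC(=O)Oc1c(OC)c(OC)c(OC(=O)CC)c2ccccc12`: 3.44
- compound 2 `COc1c(OC)c(OC(=O)C(C)(C)C)c2c(Cl)cccc2c1OC(=O)C(C)(C)C`: 6.1
- compound 3 `COc1c(OC)c(OC(C)=O)c2cc(Br)ccc2c1OC(C)=O`: 3.39

Compound 1 sits level with compound 3, as their two values lie within the usual scatter of repeated measurements. Compound 2 stands far from both of them, well beyond that scatter from compound 1.

The next compound to be measured is compound 4 `CCC(=O)Oc1c(OC)c(OC)c(OC(=O)CC)c2cc(Cl)ccc12`. It keeps the core of compound 1 and has chloro in place of hydrogen on an aromatic carbon. Among the compounds with values here, no two measured compounds differ in one place only, so the data show no direct precedent for this exchange. Compound 2 also carries a chloro group and gives 6.1, but it differs from compound 1 in other places too, so its value cannot be read as the size of this step.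

In this assay, a moderate upward step, somewhat beyond the scatter, is expected from this single exchange. The estimated change is a number 0.66 log units higher from compound 1 to compound 4 (beyond the scatter). For compound 4 the expected value is 4.1, with an estimated range from 3.7 to 4.5.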

Compound 4, partition coefficient: 4.3
The estimate for compound 4 lay 0.20 log units below the measured number, and the stated range covers the measured number.
By their numbers in this assay, from the lowest: compounds 3 and 1 (each within the scatter of the next); then compound 4; then compound 2.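

In this assay, within the data shown here, chloro in place of hydrogen on an aromatic carbon gives the first step that can be read directly, with only one place changed while the rest of compound 1 stays the same (a number 0.86 log units higher from compound 1 to compound 4 (beyond the scatter)). Among these compounds, this shows that, at this carbon of the six-membered aromatic ring of carbon only, meta to a fused ring and para to a fused ring, a single chlorine atom is enough to move the number by more than repeated measurements would scatter, something the earlier compounds, which all differ in more than one place, could not show. Nothing measured here explains the size of this step, so it stands as an observation without a known cause.

This is a single exchange on a single core, so it does not show whether the same step would appear at another carbon of the ring or with different ester chains on the core. It also leaves open how far the number would move, and in which direction, if an amine, a carboxylic acid or a longer chain took the place of chloro at this same carbon.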